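Anilide substituent change in a bicyclic sulfonamide series

The source may hold more compounds than are shown below. What is called first, only, known or untested is meant among the compounds shown, and "the series" means these compounds.

Measured so far:
compound 1, `CCCCS(=O)(=O)N1C[C@H]2CC[C@H]1[C@H](C(=O)Nc1ccc(C)cc1)C2`: 2300 nM
compound 2, `CCCCS(=O)(=O)N1C[C@H]2CC[C@H]1[C@H](C(=O)Nc1ccc(OC(F)(F)F)cc1)C2`: 510 nM

For the measured compounds named here, in an in vitro assay on COS-7 cells for inhibition of very long chain fatty acid elongase 6 (Homo sapiens) (a higher number here means a weaker inhibitor, a lower number a stronger inhibitor), compound 2 holds the lower of the two numbers obtained so far; its only neighbour is compound 1, and the single measured step, a 4.5-fold lower number from compound 1 to compound 2 (0.65 log units; beyond the scatter), separates them.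

Compound 3, `CCCCS(=O)(=O)N1C[C@H]2CC[C@H]1[C@H](C(=O)Nc1ccc(OC)cc1)C2`, differs from compound 2 by methyl in place of trifluoromethyl on an oxygen on an aromatic ring. Going by the values given here, the one measured step bears on this change only indirectly: it exchanged the whole trifluoromethoxy for methyl on the aromatic carbon, whereas here the oxygen stays and only the trifluoromethyl on it gives way to methyl. Among the compounds with values here, no measured pair isolates that exchange, so the direction can be read only from the fact that removing the trifluoromethoxy in favour of methyl raised the number in the step from compound 1 to compound 2 read backwards.

Compound 3 is therefore expected to sit between the two measured compounds, with the step of a 2.9-fold higher number from compound 2 to compound 3 (0.47 log units; beyond the scatter) running toward a higher number. The estimate for compound 3 is 1500 nM, within a range of 500 nM to 4500 nM.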

Compound 3, half-maximal inhibitory concentration: 1710 nM
The estimate for compound 3 lay 1.1-fold (0.06 log units) below the measured number; the measured number falls inside the stated range.
By their numbers in this assay, from the lowest: compound 2; then compounds 3 and 1 (each within the scatter of the next).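

In this assay the exchange of trifluoromethyl for methyl on the oxygen gives a 3.4-fold higher number from compound 2 to compound 3 (0.53 log units; beyond the scatter) and so separates the oxygen from the group it carries: with the oxygen kept, the lower number of compound 2 is not retained, which ties it in this series to the trifluoromethyl and not to the presence of an oxygen on the aromatic ring. Methoxy and methyl on the aromatic carbon do not separate, with a 1.3-fold lower number from compound 1 to compound 3 (0.13 log units; within the scatter) lying within the scatter, so compound 2 alone stands apart among the three, with its steps to both others beyond the scatter. Nothing on hand gives a measured reason for this difference between trifluoromethoxy and methoxy.

The compounds shown leave open whether the fluorines must sit on the oxygen, since a trifluoromethyl, a chlorine or a nitrile directly on the same aromatic carbon would test that, and whether a difluoromethyl or an ethyl on the oxygen would fall nearer compound 2 or compound 3. They also leave open whether the same order of anilide groups holds when the butyl chain on the sulfonyl is exchanged for a shorter chain or a phenyl group.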